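A few compounds are considered here, and "the series" means these few. Any claim that something is new, unique, unknown or untested is made for them only; others in the source may bear on it.

Compound 1 `C=Cc1ccc(-c2cc(C)c3ncc(CSCCc4ccccc4)n3c2)cc1` in an ADME assay on HEL cells (Homo sapiens) for cytotoxicity, with a stated time of 3 days (on this read-out higher numbers stand for lower toxicity in this test and lower numbers for higher toxicity in this test), gives 20 ug/mL, and stands level with compound 3 at the digits shown. Compound 3 `Cc1cc(N2CCN(C)CC2)cn2c(CSCCc3ccccc3)cnc12` gives 20 ug/mL in this assay, so the step of no change at the digits printed from compound 1 to compound 3 (within the scatter) falls within the scatter. Compound 2 `Cc1cc(-c2ccoc2)cn2c(CSCCc3ccccc3)cnc12` returns only a limit in this assay, > 4 ug/mL. One of the three values is therefore a limit: the limit of > 4 ug/mL in this assay, at which 1 of the 3 values shown sits; the steps a step that the limit leaves unreadable from compound 1 to compound 2 and a step that the limit leaves unreadable from compound 2 to compound 3 cannot be sized. Compound 4 `Cc1cc(-n2ccc3cccnc32)cn2c(CSCCc3ccccc3)cnc12` is not yet measured. It differs from compound 1 by a group of 9 heavy atoms (7 carbon, 2 nitrogen; one five-membered aromatic ring with 1 hetero atom, one six-membered aromatic ring with 1 hetero atom) in place of a group of 8 heavy atoms (8 carbon; one six-membered aromatic ring of carbon only), on an aromatic carbon. Within the data shown here, the only readable step, from compound 1 to compound 3, lies within the scatter, so no change beyond the scatter is expected here either: no change at the digits printed from compound 1 to compound 4 (within the scatter). Compound 4 is estimated at 20 ug/mL, in the range 10 ug/mL to 40 ug/mL.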

Compound 4, minimum cytotoxic concentration: 20 ug/mL
Beside the measured number, compound 4's estimate shows no gap at the digits printed, within the range that was stated.
By their numbers in this assay, from the lowest: compounds 1, 3 and 4 (each within the scatter of the next).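

In this assay, a group of 9 heavy atoms with two aromatic rings and 2 hydrogen-bond acceptors sits on this aromatic carbon with no change at the digits printed from compound 1 to compound 4 (within the scatter), and with no change at the digits printed from compound 3 to compound 4 (within the scatter). This position therefore now holds 4-vinylphenyl, 4-methylpiperazin-1-yl and this two-ring group with no difference beyond the scatter. The steps to the furan-3-yl compound 2 cannot be read, as its value is a limit: the limit of > 4 ug/mL in this assay, at which 1 of the 4 values shown sits.

Open, going by these compounds, is whether a carboxylic acid or a short alkyl chain on this carbon would shift the read-out beyond the scatter.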